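The source may report more compounds than this note shows. Statements on the series, on what has been measured and on what is new or still open speak of the compounds shown alone.

In an assay on isolated protein for inhibition of Amine oxidase [flavin-containing] A (Homo sapiens), read by fluorescence, with a stated time of 15 min (on this read-out lower numbers stand for stronger inhibition and higher numbers for weaker inhibition), three compounds of one series have been measured. Compound 1 `COc1ccc(/C=C/c2cc(OC)cc(OC)c2/C=C/C(=O)c2cc3cc(Br)cc(OC)c3oc2=O)cc1` reaches only the limit of this assay, > 60000 nM. Within the data shown here, compound 2 `CCOc1ccc2cc(C(=O)/C=C/c3c(/C=C/c4ccc(OC)cc4)cc(OC)cc3OC)c(=O)oc2c1` gives 7070 nM, and compound 3 `COc1ccc(/C=C/c2cc(OC)cc(OC)c2/C=C/C(=O)c2cc3ccc(Br)cc3oc2=O)cc1` gives 3010 nM, the lowest of the two numbers; the step of a 2.3-fold lower number from compound 2 to compound 3 (0.37 log units; beyond the scatter) is the only single change measured. Compound 4 `COc1ccc(/C=C/c2cc(OC)cc(OC)c2/C=C/C(=O)c2cc3cccc(C)c3oc2=O)cc1` has not been measured. It differs from compound 3 by a group of 12 heavy atoms (10 carbon, 2 oxygen; one six-membered aromatic ring of carbon only, one six-membered aromatic ring with 1 hetero atom) in place of a group of 12 heavy atoms (9 carbon, 2 oxygen, 1 bromine; one six-membered aromatic ring of carbon only, one six-membered aromatic ring with 1 hetero atom), on a carbonyl carbon. Among the measured compounds shown here, the one measured step, the gain on going to bromo, bears on this change only loosely, since bromo leaves and a methyl enters with the whole group; the expected step is a 2.0-fold higher number from compound 3 to compound 4 (0.30 log units; within the scatter), a modest weakening. Compound 4 is therefore estimated at 6000 nM, between 1500 nM and 25000 nM.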

Compound 4, half-maximal inhibitory concentration: > 60000 nM
Compound 4: a limit, no number (the forecaster's own chance of this, stated with the estimate: 15%); middle value at least 10-fold (1.00 log units) from the limit.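

Among these compounds, the change of the group on the carbonyl carbon gives an at least 19-fold higher number from compound 3 to compound 4 (1.29 log units; beyond the scatter), a large step, whereas the only single change seen earlier, a 2.3-fold lower number from compound 2 to compound 3 (0.37 log units; beyond the scatter), was modest. This shows that the activity of compound 3 depends strongly on the group at this place. For compound 4 the value is a limit and not a number: the limit of > 60000 nM in this assay, at which 2 of the 4 values shown sit.

The compounds shown leave open whether the loss follows from the bromine leaving or from the methyl entering, as both change together. They also leave open how a chlorine or an amine in that group would read.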